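The source may report more compounds than this note shows. Statements on the series, on what has been measured and on what is new or still open speak of the compounds shown alone.

Working notes on the series.

Three compounds have a reading in a functional assay on HeLa cells (Homo sapiens) for antiproliferative activity, read by MTT assay, with a stated time of 48 h; a lower number here means a stronger inhibitor, a higher number a weaker inhibitor. Compound 1, `CNCC(=O)Nc1cc(OC)ccc1C(=O)c1ccc(OC)c2c1OC(C)(C)C=C2`, gives 870 nM in this assay. Compound 2, `CCNCC(=O)Nc1cc(OC)ccc1C(=O)c1ccc(OC)c2c1OC(C)(C)C=C2`, carries methyl in place of hydrogen on a saturated chain carbon bound to an amine nitrogen relative to compound 1. In this assay compound 2 gives 2690 nM. Going by the values given here, that single change reads a 3.1-fold higher number from compound 1 to compound 2 (0.49 log units; beyond the scatter), the only measured instance of it so far.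

Compound 3, `C=C(c1ccc(OC)cc1NC(=O)CNC)c1ccc(OC)c2c1OC(C)(C)C=C2`, rests on a different core; the difference between the two cores is not broken down here. In this assay compound 3 gives 310 nM, the lowest of the three numbers, with compound 1 as its nearest neighbour and compound 2 as the furthest.

Compound 4, `C=C(c1ccc(OC)cc1NC(=O)CNCC)c1ccc(OC)c2c1OC(C)(C)C=C2`, has no reading yet. It carries methyl in place of hydrogen on a saturated chain carbon bound to an amine nitrogen relative to compound 3. The place is described in exactly the same words as for the pair of compounds 1 and 2, and the wider reading, methylamino to ethylamino, is the same as well, so this is taken as the same change, now set on the core of compound 3. On these data alone, whether the change carries over from one core to the other is untested, since it has been seen only once. Among the compounds with values here, the expected step from compound 3 to compound 4 is a 2.9-fold higher number from compound 3 to compound 4 (0.46 log units; beyond the scatter), because the one measured instance of the change reads a 3.1-fold higher number from compound 1 to compound 2 (0.49 log units; beyond the scatter). Compound 4 is therefore estimated at 900 nM in this assay, with the likely range running from 400 nM to 2200 nM.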

Compound 4, half-maximal inhibitory concentration: 1090 nM
Compound 4: middle estimate off by 1.2-fold (0.08 log units), on the low side; low and high end bracket the measured number.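

In this assay, methylamino to ethylamino on the core of compound 3 gives a 3.5-fold higher number from compound 3 to compound 4 (0.55 log units; beyond the scatter), so the step seen on the core of compound 1 recurs on a second core, and the two steps agree: the same change on two cores in this assay, a 3.1-fold higher number (0.49 log units; beyond the scatter) from compound 1 to compound 2 and a 3.5-fold higher number (0.55 log units; beyond the scatter) from compound 3 to compound 4, 1.1-fold (0.06 log units) apart, within the scatter of two such steps. For these two cores, then, the change carries over in both direction and size, and a step read on one core was a fair guide to the other. Going by these compounds alone, the evidence is only one matched pair on each core, so it shows neither that the step would hold on a third core nor that other changes at this place would transfer in the same way, and it gives no reason for the size of the step.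

The compounds shown leave open how the series reads with an unsubstituted amine, a longer chain such as propylamino, a branched chain such as isopropylamino, or a cyclic amine such as pyrrolidine in place of methylamino or ethylamino. They also leave open whether any of these groups would give matching steps on the two cores, as methylamino to ethylamino does.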